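The source may hold more compounds than are shown below. What is called first, only, known or untested is meant among the compounds shown, and "the series" means these compounds.

Compound 1, `COc1ccc(C2=C(c3cc(OC)c(OC)c(OC)c3)C(=O)CC2C)cc1C(=O)O`: > 100 ug/mL
Compound 2, `C=CCOc1cc(C2=C(c3cc(OC)c(OC)c(OC)c3)C(=O)C(O)C2)ccc1OC`: > 100 ug/mL

Of the compounds shown here, two have been tested in an ADME assay on KB cells (Homo sapiens) for cytotoxicity, read by MTT assay, with a stated time of 72 h (a higher number here means a weaker inhibitor, a lower number a stronger inhibitor), and both sit at a limit of the assay rather than at a number. Compound 1 `COc1ccc(C2=C(c3cc(OC)c(OC)c(OC)c3)C(=O)CC2C)cc1C(=O)O` gives > 100 ug/mL in this assay, which is a limit. Compound 2 `C=CCOc1cc(C2=C(c3cc(OC)c(OC)c(OC)c3)C(=O)C(O)C2)ccc1OC` gives > 100 ug/mL in this assay, again a limit. So compound 2 stands exactly where every value in this small set stands: the limit of > 100 ug/mL in this assay, at which 2 of the 2 values shown sit. Going by the values given here, since neither compound has a number, no measured step can be drawn between them and no direction can be read from them.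

Compound 3 `COc1ccc(C2=C(c3cc(OC)c(OC)c(OC)c3)C(=O)C(O)C2)cc1NC(=O)c1ccccc1` has not yet been measured. Compared with compound 2 it carries benzamido in place of allyloxy on an aromatic carbon; the rest of the shared core is untouched.

With every measured value resting at the limit, there is nothing pointing to a change beyond the scatter, and the step is expected to be a number no higher from compound 2 to compound 3 (the limit leaves the size open), nothing beyond the usual variation. Compound 3 is therefore expected to give about 100 ug/mL in this assay, with a range from 30 ug/mL to 300 ug/mL, and most likely the assay will again report only a limit.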

Compound 3, half-maximal inhibitory concentration: > 100 ug/mL
Compound 3 ended at the assay's limit; the forecaster's own chance of this, stated with the estimate: 65%; the middle value lies on the limit itself.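

In this assay, compound 2 and compound 3 both rest at a limit rather than at a number, so no step between them can be read: the limit of > 100 ug/mL in this assay, at which 3 of the 3 values shown sit.

The compounds shown leave open how strongly any of them acts on these cells, and whether benzamido in place of allyloxy on an aromatic carbon changes that at all.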